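Swapping chloro for trifluoromethyl at a cytotoxicity limit

A few compounds are considered here, and "the series" means these few. Any claim that something is new, unique, unknown or untested is made for them only; others in the source may bear on it.

Compound 1 `C/C(=N\NC(N)=S)c1ccc2c(c1)nc(-c1ccccc1)n2C1CCCCC1` and compound 2 `C/C(=N\NC(N)=S)c1ccc2c(c1)nc(-c1ccc(Cl)cc1)n2C1CCCCC1` share one core. In an ADME assay on MDBK cells (Bos taurus) for cytotoxicity, read by MTT assay, with a stated time of 96 h (on this read-out lower numbers stand for higher toxicity in this test and higher numbers for lower toxicity in this test), compound 1 gives 24000 nM as a measured number. Compound 2 gives > 100000 nM in this assay as a limit and not a number. Going by the values given here, the one measured step that bears on the next change puts chloro in place of hydrogen on an aromatic carbon, and it gave an at least 4.1-fold higher number from compound 1 to compound 2 (0.61 log units; beyond the scatter) with no other step at hand. Compound 3 `C/C(=N\NC(N)=S)c1ccc2c(c1)nc(-c1ccc(C(F)(F)F)cc1)n2C1CCCCC1` keeps the core and alters that same group, with trifluoromethyl in place of chloro on an aromatic carbon as the count, so trifluoromethyl stands in place of chloro. Compound 3 does not go back to the hydrogen of compound 1, which gave 24000 nM there, so no step beyond the scatter is expected in this assay and no direction can be told. The expected step reads an at least 1.1-fold lower number from compound 2 to compound 3 (0.04 log units; that floor lies within the scatter) as an estimate. For compound 3 the estimated value is 90000 nM with a range from 35000 nM to 200000 nM and it may again come back as only a limit.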

Compound 3, half-maximal cytotoxic concentration: > 100000 nM
Compound 3 gave a limit, no number (the forecaster's own chance of this, stated with the estimate: 55%); at least 1.1-fold (0.04 log units) between middle value and limit.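

In this assay, trifluoromethyl in place of hydrogen on this aromatic carbon gives an at least 4.1-fold higher number from compound 1 to compound 3 (0.61 log units; beyond the scatter). Chloro and trifluoromethyl both raise the number from that of compound 1, so at this position the rise does not depend on chloro alone. The step between compound 2 and compound 3 cannot be read, so neither group can be ranked against the other, since both compounds reach the same limit of the test: the limit of > 100000 nM in this assay, at which 2 of the 3 values shown sit.

From the compounds shown here alone, it remains open whether the rise also appears with a group that carries no halogen, such as an amine, a carboxylic acid or a methoxy group. Going by these compounds, it also remains open whether a group of a different size, such as a longer alkyl chain, would leave the number close to that of compound 1.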